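Notes on the isopropyl-bearing side chain of the fluoronaphthyl series

The compounds below may be only part of what the source reports. "The series", "measured", "known", "first", "only" and "open" are said of these compounds alone.

Measured so far in an assay on CHO cells for displacement of a labelled ligand from prostaglandin E2 receptor EP3 subtype (Homo sapiens), read by radioligand binding; a lower number here means a stronger inhibitor, a higher number a weaker inhibitor:
compound 1 `CC(C)C(c1ccc(-c2ccc3cccc(F)c3c2)[nH]c1=O)N1CCNC1=O` gives 9.1 nM;
compound 2 `CC(C)C(/C=C1/CCNC1=O)c1ccc(-c2ccc3cccc(F)c3c2)[nH]c1=O` gives 5.3 nM;
compound 3 `CC(C)C(c1ncco1)c1ccc(-c2ccc3cccc(F)c3c2)[nH]c1=O` gives 24 nM.

Compound 3 stands highest of the three numbers. Its nearest neighbour is compound 1, reached by a 2.6-fold higher number from compound 1 to compound 3 (0.42 log units; beyond the scatter); the larger gap is a 4.5-fold higher number from compound 2 to compound 3 (0.66 log units; beyond the scatter). Compound 1 and compound 2 sit within the scatter of each other, a 1.7-fold lower number from compound 1 to compound 2 (0.23 log units; within the scatter), so neither is set apart from the other.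

Compound 4 `CC(C)C(Nc1nnc[nH]1)c1ccc(-c2ccc3cccc(F)c3c2)[nH]c1=O` is not yet measured. It differs from compound 3 as follows: (4H-1,2,4-triazol-3-yl)amino in place of 1,3-oxazol-2-yl on a saturated chain carbon bound to an aromatic carbon and a saturated chain carbon. The change sits at the same place where the other three compounds differ from one another.

Going by the values given here, both steps that bear on this place, the one from compound 1 and the one from compound 2 to compound 3, run upward in number, and both lie beyond the scatter. Leaving the 1,3-oxazol-2-yl for a different five-membered group at this position has, in the two cases seen, moved the number back toward compound 1 and compound 2. A step downward of modest size is therefore expected for compound 4, estimated as a 2.2-fold lower number from compound 3 to compound 4 (0.34 log units; beyond the scatter). In this assay compound 4 is expected at about 11 nM, with a range from 4 nM to 35 nM.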

Compound 4, inhibition constant: 22 nM
The estimate for compound 4 lay 2.0-fold (0.30 log units) below the measured number, and the stated range covers the measured number.
By their numbers in this assay, from the lowest: compounds 2 and 1 (each within the scatter of the next); then compounds 4 and 3 (each within the scatter of the next).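

Exchanging 1,3-oxazol-2-yl for (4H-1,2,4-triazol-3-yl)amino on this saturated chain carbon gives a 1.1-fold lower number from compound 3 to compound 4 (0.04 log units; within the scatter) in this assay, so the two groups cannot be told apart here, although the entering group has 2 hydrogen-bond donors and the leaving group has 0. The gaps to the two compounds with a five-membered non-aromatic ring, a 2.4-fold higher number from compound 1 to compound 4 (0.38 log units; beyond the scatter) and a 4.2-fold higher number from compound 2 to compound 4 (0.62 log units; beyond the scatter), both lie beyond the scatter, and among these four compounds both groups with a five-membered aromatic ring stand at higher numbers than both groups with a non-aromatic ring, with no compound going against that split. No measurement at hand bears on what lies behind these steps.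

Compound 4 differs from compound 3 in both its ring and its amino link, so the compounds shown do not separate the two changes. Also open, going by these compounds, is how a group with no ring at all, such as a carboxylic acid or a primary amide, would stand at this position in this assay against the ring-bearing groups.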